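Furan-3-yl in place of pyrimidin-5-yl: cytotoxicity notes

The compounds below may be only part of what the source reports. "The series", "measured", "known", "first", "only" and "open" are said of these compounds alone.

In an ADME assay on J774 cells (Mus musculus) for cytotoxicity, with a stated time of 72 h (on this read-out higher numbers stand for an effect only at larger amounts of compound and lower numbers for an effect already at smaller amounts), compound 1 `COc1cc2[nH]c(C)c(-c3ccccn3)c(=O)c2cc1Cl` stands at > 33300 nM as a limit. Compound 2 `COc1cc2[nH]c(C)c(-c3cncnc3)c(=O)c2cc1Cl` stands at > 33100 nM as a limit too. Compound 3 `COc1cc2[nH]c(C)c(-c3ccc(N(C)C)nc3)c(=O)c2cc1Cl` stands at > 29100 nM as a limit too. Compound 2 therefore has no numeric position, and neither do the other two. Compound 4 `COc1cc2[nH]c(C)c(-c3ccoc3)c(=O)c2cc1Cl` has furan-3-yl in place of pyrimidin-5-yl on an aromatic carbon, with furan-3-yl in place of pyrimidin-5-yl on an aromatic carbon as the counted exchange. For the measured compounds named here, the only measured step at that place is a step that the two limits leave unreadable from compound 1 to compound 2 and it offers no size. With only that to go on, no step beyond the scatter is expected in this assay for this exchange. For compound 4 the estimate is 34000 nM and the expected range runs from 15000 nM to 60000 nM in this read-out. The estimated change amounts to a step that the limit leaves unreadable from compound 2 to compound 4 on these numbers.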

Compound 4, half-maximal effective concentration: > 34500 nM
Compound 4: a limit, no number (the forecaster's own chance of this, stated with the estimate: 80%); middle value at least 1.0-fold (0.00 log units) away from the limit.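

In this assay compound 4 stands at > 34500 nM, a limit. Compound 1 and compound 2 also stand as limits, so neither step to compound 4 can be read. As far as these compounds go, the concentration giving a half-maximal effect remains open for all four compounds.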